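Two close values and a fluoro swap

The compounds below may be only part of what the source reports. "The series", "measured", "known", "first", "only" and "open" are said of these compounds alone.

Measured so far in an ADME assay on microsomes from liver (Homo sapiens) for metabolic stability, read by LC-MS, using NADPH, with a stated time of 10 min, tested at 0.1 uM (a higher number here means faster removal of the compound, a lower number slower removal), for two compounds
- compound 1 (`COc1ccccc1N1C(=O)CSC1c1cc(F)cc(C(=O)NCCCCc2ccccc2)c1`) gives 2080 mL.min-1.g-1
- compound 2 (`Cc1cccc(N2C(=O)CSC2c2cccc(C(=O)NCCCCc3ccccc3)c2)c1`) gives 2550 mL.min-1.g-1

Compound 2 stands within the usual scatter of compound 1, so these two values cannot be told apart. Compound 3 (`O=C(NCCCCc1ccccc1)c1cccc(C2SCC(=O)N2c2cccc(F)c2)c1`) differs from compound 2 by one change (fluoro in place of methyl on an aromatic carbon), fluoro in place of methyl on an aromatic carbon, meta to a large group. Within the data shown here, no measured pair shows this swap, so the value of compound 2 (2550 mL.min-1.g-1) is the only guide in this assay for now. A small downward step is expected (a 1.3-fold lower number from compound 2 to compound 3 (0.13 log units; within the scatter)), perhaps none beyond the scatter. The estimated value for compound 3 is 1900 mL.min-1.g-1 with an expected range (950 mL.min-1.g-1 to 3500 mL.min-1.g-1).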

Compound 3, intrinsic clearance in microsomes: 1840 mL.min-1.g-1
The estimate for compound 3 lay 1.0-fold (0.01 log units) above the measured number, within the range that was stated.
By their numbers in this assay, from the lowest: compounds 3, 1 and 2 (each within the scatter of the next).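

In this assay, among these compounds, the swap of 3-methylphenyl to 3-fluorophenyl gives a 1.4-fold lower number from compound 2 to compound 3 (0.14 log units; within the scatter) and is the first single change that can be read on its own. At this place on the ring, methyl and fluoro therefore cannot be told apart by this measurement. No measured information bears on why this is so.

The compounds shown leave open how an amine or a carboxylic acid at this place would read. They also leave open whether the same swap would give a similar step on another core.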